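This account rests on a few compounds, and the source may have more. Where it says the series, first, only, none or still open, it means among the compounds named here.

Among the compounds with values here, in an assay on microsomes from brain for inhibition of Fatty-acid amide hydrolase 1 (Rattus norvegicus), read by fluorescence and HPLC, with a stated time of 60 min (a higher number here means a weaker inhibitor, a lower number a stronger inhibitor), compound 1 `CCCCCCCCc1ccc(OCC(=O)Cn2cnc3ccccc32)cc1` gives 480 nM, the highest of the two numbers measured so far. Within the data shown here, compound 2 `CCCCCCCCc1ccc(OCC(=O)Cn2nnc3ncccc32)cc1` gives 49 nM, and the one measured step, a 9.8-fold lower number from compound 1 to compound 2 (0.99 log units; beyond the scatter), shows that exchanging the ring group on that chain carbon can matter. Compound 3 `CCCCCCCCc1ccc(OCC(=O)Cn2cnnn2)cc1` is not yet measured. It differs from compound 1 by 1H-tetrazol-1-yl in place of 1H-benzimidazol-1-yl on a saturated chain carbon bound to a carbonyl carbon. Among the measured compounds shown here, only that single step bears on this change. The entering group again brings nitrogen in place of carbon but is smaller, so a more modest gain is expected, a 2.4-fold lower number from compound 1 to compound 3 (0.38 log units; beyond the scatter). Compound 3 is therefore estimated at 200 nM, within 60 nM to 700 nM.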

Compound 3, half-maximal inhibitory concentration: 39 nM
For compound 3 the middle estimate is 5.1-fold (0.71 log units) above the measured one; measured number below the stated range.
By their numbers in this assay, from the lowest: compounds 3 and 2 (each within the scatter of the next); then compound 1.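

Placing 1H-tetrazol-1-yl on this chain carbon gives a 12-fold lower number from compound 1 to compound 3 (1.09 log units; beyond the scatter) in this assay and shows that a low number does not need a six-membered aromatic ring here. The comparison with the two-ring group gives a 1.3-fold lower number from compound 2 to compound 3 (0.10 log units; within the scatter) and shows no real difference, so heavy-atom count alone does not set the number among these compounds. No measurement shown explains these results. Still open, from the compounds shown here alone, is whether 1H-imidazol-1-yl, a single five-membered ring with fewer nitrogens, would behave like 1H-tetrazol-1-yl or more like 1H-benzimidazol-1-yl.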